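A few compounds are considered here, and "the series" means these few. Any claim that something is new, unique, unknown or untested is made for them only; others in the source may bear on it.

Compound 1 `COc1ccc(/C=N\NC(=S)NC(C)(C)CCC[C@](C)(O)[C@@H]2CC=C(C)CC2)cc1`: 6500 nM
Compound 2 `CC1=CC[C@@H]([C@@](C)(O)CCCC(C)(C)NC(=S)N/N=C\c2ccc(O)cc2)CC1`: 6230 nM

In a functional assay on OVCAR-3 cells (Homo sapiens) for cytotoxicity, read by sulforhodamine B assay (a higher number here means a weaker inhibitor of growth, a lower number a stronger inhibitor of growth), compound 1 gives 6500 nM and compound 2 gives 6230 nM. Among the compounds with values here, the one measured step, a 1.0-fold lower number from compound 1 to compound 2 (0.02 log units; within the scatter), changes nothing of note. Compound 2 thus stands level with compound 1, the two numbers lying within the scatter of each other.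

Compound 3 `CC1=CC[C@@H]([C@@](C)(O)CCCC(C)(C)NC(=S)N/N=C\c2ccccc2[N+](=O)[O-])CC1` differs from compound 2 by 2-nitrophenyl in place of 4-hydroxyphenyl on a carbon with a double bond to nitrogen. Within the data shown here, the only measured step alters the same ring and stays within the scatter, and no measured step touches a nitro group. Compound 3 is therefore expected to show no step beyond the scatter, a 1.0-fold lower number from compound 2 to compound 3 (0.02 log units; within the scatter), with an estimate of 6000 nM and a range from 2000 nM to 18000 nM.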

Compound 3, concentration for 50% growth inhibition: 7390 nM
The estimate for compound 3 lay 1.2-fold (0.09 log units) below the measured number, within the range that was stated.
By their numbers in this assay, from the lowest: compounds 2, 1 and 3 (each within the scatter of the next).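

Placing 2-nitrophenyl on the carbon with a double bond to nitrogen gives a 1.2-fold higher number from compound 2 to compound 3 (0.07 log units; within the scatter) in this assay when it replaces 4-hydroxyphenyl, and a 1.1-fold higher number from compound 1 to compound 3 (0.06 log units; within the scatter) when it replaces 4-methoxyphenyl. At this position, then, the nitro-bearing ring stands level with both oxygen-bearing rings, so the tolerance seen earlier for a small change on the oxygen extends to a change of the whole aryl group. No available evidence bears on why these numbers stay level. On these data alone, whether an amine or a carboxylic acid on this ring would move the number beyond the scatter remains open.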